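A few compounds are considered here, and "the series" means these few. Any claim that something is new, unique, unknown or untested is made for them only; others in the source may bear on it.

Measured so far in a physicochemical assay for lipophilicity, read by HPLC, measured as octanol-water partition, at pH 7.4 (on this read-out lower numbers stand for lower lipophilicity and higher numbers for higher lipophilicity), are:
- compound 1 `CC1(C)CO[C@@H]1CN([C@H](CCC(F)(F)F)C(N)=O)S(=O)(=O)c1ccc(Cl)cc1` with 3.9
- compound 2 `NC(=O)[C@@H](CCC(F)(F)F)N(C[C@H]1CCCOC1)S(=O)(=O)c1ccc(Cl)cc1` with 3.6
- compound 3 `NC(=O)[C@@H](CCC(F)(F)F)N(CC1CCOCC1)S(=O)(=O)c1ccc(Cl)cc1` with 3.5

Compound 3 stands clear of compound 1 (a number 0.40 log units lower from compound 1 to compound 3 (beyond the scatter)) but cannot be told apart from compound 2 (a number 0.10 log units lower from compound 2 to compound 3 (within the scatter)).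

Compound 4 `NC(=O)[C@@H](CCC(F)(F)F)N(C[C@@H]1CCOC1)S(=O)(=O)c1ccc(Cl)cc1` is still unmeasured. It has oxolan-3-yl in place of oxan-4-yl on a saturated chain carbon bound to a sulfonamide nitrogen. A five-membered non-aromatic ring thus replaces a six-membered one.

Among the measured compounds shown here, no measured step brings in oxolan-3-yl, so the evidence is indirect. For the measured compounds named here, the three exchanges at this place among compounds 1, 2 and 3 are the only guide. Besides the two steps above, they include one more (a number 0.30 log units lower from compound 1 to compound 2 (within the scatter)). Going by the values given here, all three are small, and only the step to compound 3 from compound 1 passes the scatter, and then modestly.

A similarly small change in this assay is therefore expected, with nothing clearly beyond the scatter. A slight lean towards a lower number rests only on the smaller heavy-atom count of the entering group, which is weak support. The expected step is small (a number 0.20 log units lower from compound 3 to compound 4 (within the scatter)). For compound 4 the estimated value is 3.3, with an expected range from 3 to 3.6.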

Compound 4, distribution coefficient: 2.8
Compound 4: middle estimate off by 0.50 log units, on the high side; the whole stated range lies above it.
By their numbers in this assay, from the lowest: compound 4; then compounds 3, 2 and 1 (each within the scatter of the next, the first and the last beyond it).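

At this place, on a saturated chain carbon bound to a sulfonamide nitrogen, this assay separates ring groups of like make-up: oxolan-3-yl stands clear of oxan-4-yl (a number 0.70 log units lower from compound 3 to compound 4 (beyond the scatter)) and of oxan-3-yl (a number 0.80 log units lower from compound 2 to compound 4 (beyond the scatter)), whereas the two oxan groups cannot be told apart (a number 0.10 log units lower from compound 2 to compound 3 (within the scatter)). Among the compounds shown here, the exchange for 3,3-dimethyloxetan-2-yl gives the first large step at this place (a number 1.10 log units lower from compound 1 to compound 4 (beyond the scatter)). Among the measured groups, the oxan groups and oxolan-3-yl carry 1 hydrogen-bond acceptor each, so a move from a six-membered to a five-membered non-aromatic ring, from 6 heavy atoms to 5, goes with a clear shift in the read-out, and no supporting data are available to account for its size.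

Still open, as far as these compounds go, is whether this low number belongs to the five-membered ring in general or to this form of oxolan-3-yl with its defined stereocentre, and whether oxolan-2-yl would read alike. Also open, from the compounds shown here alone, is how an amine such as pyrrolidin-3-yl, or an open ether chain such as 2-methoxyethyl, would read at this place.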